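The compounds below may be only part of what the source reports. "The series", "measured", "known", "first", "only" and "open" are said of these compounds alone.

Compound 1 `C[C@H]1CN(C2CCN(c3n[nH]c(N)n3)CC2)[C@@H](Cc2ccc(Cl)cc2)CN1Cc1ccc(Cl)cc1` carries a 4-chlorobenzyl group on the amine nitrogen of its saturated ring. In an assay on isolated protein for inhibition of chitotriosidase-1 (Mus musculus), read by fluorescence, with a stated time of 60 min (a lower number here means a stronger inhibitor, a higher number a weaker inhibitor), compound 1 gives 495 nM, the highest of the three numbers recorded so far. Compound 3 `C[C@H]1CN(C2CCN(c3n[nH]c(N)n3)CC2)[C@@H](Cc2ccc(Cl)cc2)CN1CC(=O)O` gives 53 nM. Compound 2 `CC(C)C[C@H]1CN(C2CCN(c3n[nH]c(N)n3)CC2)[C@@H](Cc2ccc(Cl)cc2)CN1CC(C)C` differs from compound 1 in several places, and compound 2 gives 41 nM. Going by the values given here, the one single-point step available runs a 9.3-fold lower number from compound 1 to compound 3 (0.97 log units; beyond the scatter): giving up the 4-chlorophenyl on a saturated chain carbon bound to an amine nitrogen in a ring lowered the number clearly. Compound 4 `COC(=O)N1C[C@H](Cc2ccc(Cl)cc2)N(C2CCN(c3n[nH]c(N)n3)CC2)C[C@@H]1C` has not yet been measured; against compound 1 it shows (methoxycarbonyl in place of 4-chlorobenzyl on an amine nitrogen in a ring). Among the compounds with values here, this change again takes the 4-chlorobenzyl away from the ring nitrogen, so the step from compound 1 to compound 3 is the only guide, and it points to a lower number; since the group that enters differs from the carboxy of compound 3, a somewhat more modest step is expected: a 4.5-fold lower number from compound 1 to compound 4 (0.65 log units; beyond the scatter). Compound 4 is therefore expected to give 110 nM, with a likely range from 30 nM to 400 nM.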

Compound 4, half-maximal inhibitory concentration: 461 nM
Beside the measured number, compound 4's estimate is 4.2-fold (0.62 log units) below it; the whole stated range lies below it.
By their numbers in this assay, from the lowest: compounds 2 and 3 (each within the scatter of the next); then compounds 4 and 1 (each within the scatter of the next).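

In this assay, 4-chlorobenzyl and methoxycarbonyl on the amine nitrogen in a ring cannot be told apart, with the step reading (a 1.1-fold lower number from compound 1 to compound 4 (0.03 log units; within the scatter)). The group that enters therefore matters, for on that same nitrogen the change from carboxymethyl to methoxycarbonyl gives (an 8.7-fold higher number from compound 3 to compound 4 (0.94 log units; beyond the scatter)). The lower number of compound 3 thus cannot be credited to the loss of the 4-chlorobenzyl alone: among these three single-place comparisons it goes with the carboxymethyl group, and compound 4, which also lacks the 4-chlorobenzyl, does not share it.

No evidence here accounts for the difference between the carboxymethyl and methoxycarbonyl groups. The compounds shown leave open whether a free carboxylic acid is needed at this nitrogen, or whether a primary amide or a longer chain ending in a carboxylic acid would give a similar number.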